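The compounds below may be only part of what the source reports. "The series", "measured", "known", "first", "only" and "open" are said of these compounds alone.

Measured so far in an ADME assay on GES1 cells (Homo sapiens) for cytotoxicity, read by MTT assay, with a stated time of 24 h; on this read-out lower numbers stand for higher toxicity in this test and higher numbers for lower toxicity in this test:
compound 1 `O=c1[nH]cc(S(=O)(=O)Nc2cccc(-c3cn(-c4ccccc4)nn3)c2)c(=O)[nH]1` — 22500 nM
compound 2 `Cc1cccc(-n2cc(-c3cccc(NS(=O)(=O)c4c[nH]c(=O)[nH]c4=O)c3)nn2)c1` — 18500 nM
compound 3 `O=c1[nH]cc(S(=O)(=O)Nc2ccc(-c3cn(-c4ccccc4)nn3)cc2)c(=O)[nH]1` — "not toxic" (no number reported), no number given

Compounds 1 and 2 share a core; the step of a 1.2-fold lower number from compound 1 to compound 2 (0.09 log units; within the scatter) is the effect of methyl in place of hydrogen on an aromatic carbon, and it lies within the scatter, so the two values are read as the same. Compound 3 has the same atoms as compound 1 joined differently; the difference between the two cores is not broken down here. Compound 3 is described in this assay only as "not toxic" (no number reported), so no number stands for it.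

Compound 4 `Cc1ccccc1-n1cc(-c2ccc(NS(=O)(=O)c3c[nH]c(=O)[nH]c3=O)cc2)nn1` is the unmeasured member. It differs from compound 3 by methyl in place of hydrogen on an aromatic carbon. Among the compounds with values here, this is the same kind of change as the one from compound 1 to compound 2, but not the same: in the earlier pair the methyl sits meta to a large group, in the new pair it sits ortho to a large group.

Expectation for this assay: the one measured example of a methyl entering an aromatic carbon, the step from compound 1 to compound 2, left the read-out within the scatter, so the same kind of change from compound 3 to compound 4 is expected to leave the read-out where compound 3 stands, with the caveat that compound 3 carries no number and the place of the methyl differs. Compound 4 is therefore expected to show low toxicity in this assay, with an estimated half-maximal cytotoxic concentration around 30000 nM, and a range from 12000 nM to 100000 nM is expected to hold it, allowing for the chance that, as for compound 3, only a qualitative outcome and no number is reported.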

Compound 4, half-maximal cytotoxic concentration: "not toxic" (no number reported)
For compound 4 the study gives words and no number; the estimate stays without a comparison.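

In this assay, within the data shown here, compound 3 and compound 4 are both described only in words, so no step between them can be read. The compounds shown leave open whether methyl in place of hydrogen, ortho to a large group, shifts the read-out in this pair as little as a 1.2-fold lower number from compound 1 to compound 2 (0.09 log units; within the scatter). No supporting data bear on this result.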